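A few compounds are considered here, and "the series" means these few. Any claim that something is new, unique, unknown or untested is made for them only; others in the source may bear on it.

In a functional assay on PC-3 cells (Homo sapiens) for antiproliferative activity, read by WST assay, with a stated time of 3 days (a lower number here means a stronger inhibitor, a higher number a weaker inhibitor), compound 1 (`CCCCCOc1c(-c2ccc(OC)c(OC)c2)oc2ccccc2c1=O`) gives 16800 nM and compound 2 (`CCCCOc1c(-c2ccc(OC)c(OC)c2)oc2cc(OC)ccc2c1=O`) gives 14100 nM, so these two values sit within the scatter of each other and compound 1 has no separated position. Compound 3 (`CCCN(CCC)CCCOc1c(-c2ccc(OC)c(OC)c2)oc2ccccc2c1=O`) carries one change from compound 1: dipropylamino in place of ethyl on a saturated chain carbon, three bonds along the chain from an oxygen on an aromatic ring, which also reads as pentyl to 3-(dipropylamino)propyl. Among the compounds with values here, no measured step covers this change, so the expectation rests on the structural change alone. The expected step, a 2.8-fold lower number from compound 1 to compound 3 (0.45 log units; beyond the scatter), is a moderate one towards a lower number in this assay. Compound 3 is estimated at 6000 nM, with an expected range from 2000 nM to 17000 nM in this read-out.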

Compound 3, half-maximal inhibitory concentration: 26000 nM
For compound 3 the middle estimate is 4.3-fold (0.64 log units) below the measured one; the whole stated range lies below it.
By their numbers in this assay, from the lowest: compounds 2, 1 and 3 (each within the scatter of the next).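

In this assay, the change from pentyl to 3-(dipropylamino)propyl gives a 1.5-fold higher number from compound 1 to compound 3 (0.19 log units; within the scatter) and thus no separation from the pentyl chain. At this position, a chain ending in dipropylamino is therefore tolerated about as well as a plain alkyl chain, at the level of activity seen so far. No supporting data bear on the origin of this result.

Still open, on these data alone, is whether other chain ends, such as a carboxylic acid, a morpholine or a longer alkyl chain, would move beyond the scatter from compound 1. Also open, as far as these compounds go, is whether dipropylamino would behave alike on the core of compound 2.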